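Small change on a weakly active set of compounds

The compounds below may be only part of what the source reports. "The series", "measured", "known", "first", "only" and "open" are said of these compounds alone.

- compound 1 `O=C1COc2ccc(-c3cnc(Cl)c(NS(=O)(=O)c4ccc(F)cc4)c3)cc2N1C1CCCCC1`: 14300 nM
- compound 2 `COc1ncc(-c2ccc3c(c2)NC(=O)CO3)cc1NS(=O)(=O)c1ccc(F)cc1`: 7110 nM
- compound 3 `COc1ncc(-c2ccc3c(c2)N(c2ccc(F)cc2)C(=O)CO3)cc1NS(=O)(=O)c1ccc(F)cc1`: 10500 nM

In a functional assay on HeLa cells (Homo sapiens) for antiproliferative activity, read by MTT assay, with a stated time of 72 h (on this read-out lower numbers stand for stronger inhibition and higher numbers for weaker inhibition), compound 2 gives 7110 nM, and its gaps to the other two values stay within the usual scatter, so the three cannot be ranked. Compound 4 `O=C1COc2ccc(-c3cnc(Cl)c(NS(=O)(=O)c4ccc(F)cc4)c3)cc2N1` differs from compound 2 at one place: chloro in place of methoxy on an aromatic carbon. For the measured compounds named here, no measured step makes this exact change. Going by the values given here, the only step available, a 1.5-fold higher number from compound 2 to compound 3 (0.17 log units; within the scatter), alters another part of the structure and stays within the scatter. Compound 1, which also carries chloro but differs elsewhere, gives 14300 nM. A slightly higher number, with no shift beyond the scatter, is therefore expected in this assay. The expected step is a 1.4-fold higher number from compound 2 to compound 4 (0.15 log units; within the scatter). For compound 4 the estimated value is 10000 nM, with an expected range of 4000 nM to 25000 nM.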

Compound 4, half-maximal inhibitory concentration: 15600 nM
The estimate for compound 4 lay 1.6-fold (0.19 log units) below the measured number; low and high end bracket the measured number.
By their numbers in this assay, from the lowest: compounds 2, 3, 1 and 4 (each within the scatter of the next, the first and the last beyond it).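

In this assay, for the compounds shown here, chloro in place of methoxy on the aromatic carbon next to the ring nitrogen gives a 2.2-fold higher number from compound 2 to compound 4 (0.34 log units; beyond the scatter), a modest step and the first measured change at this position. With chloro held in place, hydrogen in place of cyclohexyl on the amide-type nitrogen gives a 1.1-fold higher number from compound 1 to compound 4 (0.04 log units; within the scatter), so these two cannot be told apart. Nothing shown here explains the methoxy-to-chloro step. On these data alone, whether an amine or ethoxy at this position would give a lower number stays open. So does whether the step would hold with 4-fluorophenyl on the amide-type nitrogen.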